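The source may hold more compounds than are shown below. What is called first, only, known or untested is meant among the compounds shown, and "the series" means these compounds.

Measured so far in a functional assay on GTL 16 cells for antiproliferative activity against GTL 16 cell line (Homo sapiens), read by CCK-8 assay, with a stated time of 72 h; on this read-out lower numbers stand for stronger inhibition and higher numbers for weaker inhibition:
compound 1, `O=C(Nc1cccc(-c2oc3cc(-c4ccc(F)cc4)ccc3c(=O)c2O)c1)c1ccccc1F`, 17400 nM
compound 2, `COc1ccc(C(=O)Nc2cccc(-c3oc4cc(-c5ccc(F)cc5)ccc4c(=O)c3O)c2)cc1`, 21100 nM

Compound 2 and compound 1 sit within the scatter of each other: the step of a 1.2-fold higher number from compound 1 to compound 2 (0.08 log units; within the scatter). Compound 3, `O=C(Nc1cccc(-c2oc3cc(-c4ccc(F)cc4)ccc3c(=O)c2O)c1)c1ccc(Cl)cc1`, differs from compound 2 by chloro in place of methoxy on an aromatic carbon. Within the data shown here, the only step measured so far, a 1.2-fold higher number from compound 1 to compound 2 (0.08 log units; within the scatter), exchanged one aryl group on the carbonyl carbon for another and stayed within the scatter, so a further exchange of the same kind is expected to move this assay by a step of a 1.1-fold lower number from compound 2 to compound 3 (0.02 log units; within the scatter), none beyond the scatter. Compound 3 is therefore estimated at 20000 nM, within 8000 nM to 50000 nM.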

Compound 3, half-maximal inhibitory concentration: 9140 nM
Compound 3: middle estimate off by 2.2-fold (0.34 log units), on the high side; low and high end bracket the measured number.
By their numbers in this assay, from the lowest: compounds 3, 1 and 2 (each within the scatter of the next, the first and the last beyond it).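

Among these compounds, on the aromatic carbon para to a large group, chloro in place of methoxy gives a 2.3-fold lower number from compound 2 to compound 3 (0.36 log units; beyond the scatter) in this assay, the first step beyond the scatter, so this position does respond to substitution, if modestly. Set against 2-fluorophenyl on the carbonyl carbon, 4-chlorophenyl gives only a 1.9-fold lower number from compound 1 to compound 3 (0.28 log units; within the scatter) and sets no order between the two. No measurement on hand bears on why chloro differs from methoxy here.

On these data alone, whether an amine or a carboxylic acid at this carbon would hold or lose the step stays open. So does the effect of chloro on another carbon of the same ring.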